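This account rests on a few compounds, and the source may have more. Where it says the series, first, only, none or still open, it means among the compounds named here.

Measured so far:
compound 1, `O=C(Nc1ccc(-n2ccc3c(NC(=O)c4ccccc4)nccc32)cc1)Nc1cccc(Cl)c1Cl`, in a functional assay on A-375 cells (Homo sapiens) for antiproliferative activity, read by MTT assay, with a stated time of 48 h, in the presence of a further agent that is not named here (a higher number here means a weaker inhibitor, a lower number a stronger inhibitor), gives > 10000 nM
compound 2, `Cc1cc(NC(=O)Nc2cccc(Cl)c2Cl)ccc1-n1ccc2c(NC(=O)c3ccccc3)nccc21`, gives > 10000 nM
compound 3, `Nc1nccc2c1ccn2-c1ccc(NC(=O)Nc2ccc(Cl)c(C(F)(F)F)c2)cc1`, gives 8000 nM

Compound 2 stands at a limit of this assay rather than at a number, its value being > 10000 nM. Compound 1 likewise sits at a limit, > 10000 nM. Among the measured compounds shown here, the only step measured within this set, a step that the two limits leave unreadable from compound 1 to compound 2, therefore cannot be read, because both ends rest on (the limit of > 10000 nM in this assay, at which 2 of the 3 values shown sit). Compound 3, with a free amine on its core and a different phenyl on the urea, gives 8000 nM, a number but a weak one.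

Compound 4, `Cc1cc(NC(=O)c2ccc(Cl)c(C(F)(F)F)c2)ccc1-n1ccc2c(NC(=O)c3ccccc3)nccc21`, differs from compound 2 in one place: 4-chloro-3-(trifluoromethyl)phenyl in place of (2,3-dichlorophenyl)amino on a carbonyl carbon. For the measured compounds named here, no measured step concerns this change; the single step on record deals with a methyl group and is itself unreadable. Compound 3 carries the same 4-chloro-3-(trifluoromethyl)phenyl, but on another core and through a different linkage, so its value and that of compound 2 show only that neither reaches strong inhibition.

On this basis compound 4 is expected to remain in the weak region, with the step that the limit leaves unreadable from compound 2 to compound 4 estimated as none that can be resolved against a limit. The estimate for compound 4 is 15000 nM, within 4000 nM to 60000 nM.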

Compound 4, half-maximal inhibitory concentration: 2700 nM
Compound 4: middle estimate off by 5.6-fold (0.74 log units), on the high side; the measured number lies below the stated range.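

In this assay, the change on the carbonyl carbon gives a step that can be read, unlike the step between compound 1 and compound 2, which cannot: 4-chloro-3-(trifluoromethyl)phenyl in place of (2,3-dichlorophenyl)amino brings an at least 3.7-fold lower number from compound 2 to compound 4 (0.56 log units; beyond the scatter). From the compounds shown here alone, compound 2 stands at a limit, > 10000 nM, so this step gives only a minimum size, and its full size stays unknown: the limit of > 10000 nM in this assay, at which 2 of the 4 values shown sit. The change also replaces the urea of compound 2 with an amide, since the group that leaves carries one hydrogen-bond donor and the group that enters carries none, so at this position the urea is not required for compound 4 to give a measurable number.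

The compounds shown do not separate the part played by the 4-chloro-3-(trifluoromethyl)phenyl ring from the part played by the loss of the amino link, and a urea bearing that same ring on the core of compound 4 would be needed to do so. Also open, going by these compounds, is how other groups on this carbonyl carbon, such as a morpholine, a carboxylic acid or a longer alkyl chain, would read in this assay.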